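Cytotoxicity notes on the shared core, compound 1 to compound 4

This account rests on a few compounds, and the source may have more. Where it says the series, first, only, none or still open, it means among the compounds named here.

Measured in an ADME assay on NCM460 cells (Homo sapiens) for cytotoxicity, read by MTT assay, with a stated time of 72 h; on this read-out lower numbers stand for stronger inhibition and higher numbers for weaker inhibition:
- compound 1 `O=C(Nc1ccc(OC(F)F)cc1)c1cccc(/C=C2\CC(=O)N(c3ccccc3)C2=O)c1`, a limit only: > 100000 nM
- compound 2 `COc1ccc(NC(=O)c2cccc(/C=C3\CC(=O)N(c4ccc(C)cc4)C3=O)c2)cc1`, a limit only: > 100000 nM
- compound 3 `CCCCCN1C(=O)C/C(=C\c2cccc(C(=O)NCCCC)c2)C1=O`, a limit only: > 100000 nM

Compound 1 stands at a limit of this assay, not at a number. Compound 2 and compound 3 stand at the same limit: the limit of > 100000 nM in this assay, at which 3 of the 3 values shown sit. Among the measured compounds shown here, no step between measured compounds is available here, so nothing is known of how the side groups move the read-out. Compound 4 `O=C(Nc1ccc(F)cc1)c1cccc(/C=C2\CC(=O)N(c3ccccc3)C2=O)c1` is the analogue still to be measured. It differs from compound 1 in one place: fluoro in place of difluoromethoxy on an aromatic carbon. Because compound 1 and likewise compound 2 and compound 3 rest at the limit of > 100000 nM in this assay, at which 3 of the 3 values shown sit, the step is expected to be none beyond the scatter: a step that the limit leaves unreadable from compound 1 to compound 4. Compound 4 is accordingly expected to give about 150000 nM in this assay, estimated between 60000 nM and 400000 nM, and most likely reported again only as a limit.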

Compound 4, half-maximal inhibitory concentration: > 100000 nM
Compound 4 ended at the assay's limit (the forecaster's own chance of this, stated with the estimate: 85%); the middle value is on the limit's open side.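

Among the compounds shown here, no step from compound 1 to compound 4 can be read, as both compounds rest at a limit: the limit of > 100000 nM in this assay, at which 4 of the 4 values shown sit.

The compounds shown leave open whether any change on the shared core brings a measurable value in this assay.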